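The source may report more compounds than this note shows. Statements on the series, on what has been measured and on what is new or still open speak of the compounds shown alone.

Compound 1 `O=C(O)c1ccccc1-c1ccc(CCc2ncc(Cc3cccc(Cl)c3)[nH]2)cc1`: 31 nM in an in vitro functional assay on cells for agonist activity at Bombesin receptor subtype-3 (Mus musculus), read by luminescence and calcium flux; a higher number here means that more compound is needed for the effect, a lower number that less compound is needed
Compound 2 `Cc1cccc(Cc2cnc(CCc3ccc(-c4ccccc4C(=O)O)cc3)[nH]2)c1`: 75 nM
Compound 3 `CC(C)(C)c1cnc(CCc2ccc(-c3ccccc3C(=O)O)cc2)[nH]1`: 2750 nM

Compound 3 has the highest number of the three in this assay. Compound 4 `Cc1ccccc1Cc1cnc(CCc2ccc(-c3ccccc3C(=O)O)cc2)[nH]1` differs from compound 3 by 2-methylbenzyl in place of tert-butyl on an aromatic carbon. Going by the values given here, two measured steps bear on this change: an 89-fold higher number from compound 1 to compound 3 (1.95 log units; beyond the scatter) and a 37-fold higher number from compound 2 to compound 3 (1.56 log units; beyond the scatter), both large, and both show that putting tert-butyl in place of a benzyl group raised the number strongly. Restoring a benzyl group is therefore expected to lower the number by a large step. Among the compounds with values here, no measured compound carries the 2-methylbenzyl group itself, so some uncertainty remains. Compound 4 is expected to give 100 nM, with a likely range of 30 nM to 400 nM, which is expected to mean a 28-fold lower number from compound 3 to compound 4 (1.44 log units; beyond the scatter).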

Compound 4, half-maximal effective concentration: 9.3 nM
For compound 4 the middle estimate is 11-fold (1.03 log units) above the measured one; measured number below the stated range.
By their numbers in this assay, from the lowest: compound 4; then compound 1; then compound 2; then compound 3.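

In this assay, going by these compounds alone, the large benzyl-type group does more than recover what tert-butyl lost, with a 300-fold lower number from compound 3 to compound 4 (2.47 log units; beyond the scatter), and the earlier compounds did not show that the substituent's place on the benzyl ring also matters. With 2-methylphenyl in place of 3-methylphenyl there is an 8.1-fold lower number from compound 2 to compound 4 (0.91 log units; beyond the scatter), and with 2-methylphenyl in place of 3-chlorophenyl there is a 3.3-fold lower number from compound 1 to compound 4 (0.52 log units; beyond the scatter), so compound 4 has the lowest number of the four. Nothing available explains these differences. From the compounds shown here alone, whether 2-chlorobenzyl would match 2-methylbenzyl remains open. So does the effect of a methoxy group or an amine on that benzyl ring.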